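The source may report more compounds than this note shows. Statements on the series, on what has been measured and on what is new or still open speak of the compounds shown alone.

Measured in an ADME assay on cells (Epithelial cell, Homo sapiens) for antiproliferative activity, read by MTT assay, with a stated time of 48 h; on this read-out lower numbers stand for stronger inhibition and higher numbers for weaker inhibition:
- compound 1 `COC(=O)/C(=C/c1ccccc1)CN1C(=O)[C@@H](OC)[C@H]1c1ccccc1C(F)(F)F`: "not toxic" (no number reported)
- compound 2 `CCOC(=O)/C(=C/c1ccccc1)CN1C(=O)[C@@H](OC)[C@H]1c1ccccc1Br`: 66600 nM
- compound 3 `COC(=O)/C(=C/c1ccccc1)CN1C(=O)[C@@H](OC)[C@H]1c1ccccc1`: "not toxic" (no number reported)

Compound 1 has no single number to place on a scale. Its entry in this assay is only a verbal result, and compound 3 likewise gives "not toxic" (no number reported). Compound 2 is the only one of the three with a number, at 66600 nM.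

Compound 4 `COC(=O)/C(=C/c1ccccc1)CN1C(=O)[C@@H](OC)[C@H]1c1cccc([N+](=O)[O-])c1` has not yet been measured. It keeps the core of compound 1 and changes one group: 3-nitrophenyl in place of 2-(trifluoromethyl)phenyl on a saturated ring carbon, next to the ring nitrogen (3-nitrophenyl in place of 2-(trifluoromethyl)phenyl on a saturated ring carbon).

Going by the values given here, with no number for compound 1 and no measured step between related compounds, the size of this step cannot be worked out from the data. The expectation is therefore qualitative. Compound 4 should stay weak in this assay, with no large move toward stronger inhibition. It may well return a verbal result with no number. Among the compounds with values here, the only numerical anchor is compound 2 at 66600 nM, so any number should lie in that region. If a number is reported, compound 4 is estimated at 60000 nM, with an expected range of 20000 nM to 150000 nM.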

Compound 4, half-maximal inhibitory concentration: "not toxic" (no number reported)
For compound 4 the study gives words and no number; there is nothing to compare the estimate with.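

In this assay, going by these compounds alone, compound 1 gives "not toxic" (no number reported) and compound 4 gives "not toxic" (no number reported) and with no number on either side, no step between them can be read. The compounds shown leave open whether 3-nitrophenyl in place of 2-(trifluoromethyl)phenyl shifts activity at all, and by how much. No measured evidence bears on this result.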